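This account rests on a few compounds, and the source may have more. Where it says the series, first, only, none or still open, it means among the compounds named here.

Going by the values given here, compound 1 `C=CC[C@H]1C[C@]2([C@@H](C)Cc3ccccc3)OCOC2=CC1=O` gives 9700 nM in a functional assay on NCI-H460 cells (Homo sapiens) for antiproliferative activity, with a stated time of 72 h (a lower number here means a stronger inhibitor, a higher number a weaker inhibitor), and stands highest of the two numbers so far; its nearest neighbour is compound 2 `C=CC[C@H]1C[C@]2([C@@H](C)Cc3ccc(OC(F)(F)F)cc3)OCOC2=CC1=O`, which gives 3800 nM. Among the compounds with values here, the one measured step, a 2.6-fold lower number from compound 1 to compound 2 (0.41 log units; beyond the scatter), is the sole comparison. Compound 3 `C=CC[C@H]1C[C@]2([C@@H](C)Cc3ccc(OC)nc3)OCOC2=CC1=O` is not yet measured; it differs from compound 1 by 6-methoxypyridin-3-yl in place of phenyl on a saturated chain carbon, two bonds along the chain from a saturated ring carbon. Within the data shown here, no measured step changes the aromatic ring itself, so the step from compound 1 to compound 2 bears on compound 3 only loosely, as a sign that a substituent on that ring shifted this assay by a modest amount. On that basis a small move in the same direction, or none beyond the scatter, is expected for compound 3, i.e. an estimated 1.8-fold lower number from compound 1 to compound 3 (0.25 log units; within the scatter). Compound 3 is therefore estimated at 5500 nM in this assay, with a range from 1800 nM to 17000 nM.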

Compound 3, half-maximal inhibitory concentration: 330 nM
Compound 3: the middle estimate sits 17-fold (1.22 log units) above what was measured, and the stated range ends above it.
By their numbers in this assay, from the lowest: compound 3; then compound 2; then compound 1.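

Exchanging phenyl for 6-methoxypyridin-3-yl on a saturated chain carbon, two bonds along the chain from a saturated ring carbon, gives a 29-fold lower number from compound 1 to compound 3 (1.47 log units; beyond the scatter) in this assay. The earlier change on this aromatic ring, a 2.6-fold lower number from compound 1 to compound 2 (0.41 log units; beyond the scatter), kept the phenyl and was modest, so this position can shift the read-out far more than that step alone indicated. No measurement bears on why the number falls so far.

The change brings in the ring nitrogen and the methoxy together, and the compounds shown do not separate their contributions: a pyridin-3-yl with no methoxy and a phenyl carrying methoxy would do so. Also open, from the compounds shown here alone, is whether the methoxy can give way to an ethoxy or an amine on the same pyridine.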